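Methoxy to ethoxy on the 2-methoxyphenyl compound

A few compounds are considered here, and "the series" means these few. Any claim that something is new, unique, unknown or untested is made for them only; others in the source may bear on it.

Compound 1 `CCCc1ccc(NC2=CC(=O)c3nc4n(c3C2=O)[C@H]2OC[C@@H](O)[C@H]2OC4)cc1` reads 4660 nM in a functional assay on MCF7 cells (Homo sapiens) for inhibition, read by sulforhodamine B assay (a lower number here means a stronger inhibitor, a higher number a weaker inhibitor), as a measured number. Compound 2 `COc1ccccc1NC1=CC(=O)c2nc3n(c2C1=O)[C@H]1OC[C@@H](O)[C@H]1OC3` reads > 4000 nM in this assay and this is a limit, not a number. For the measured compounds named here, the only measured change is a step that the limit leaves unreadable from compound 1 to compound 2 and it gives no size to carry over. Compound 3 `CCOc1ccccc1NC1=CC(=O)c2nc3n(c2C1=O)[C@H]1OC[C@@H](O)[C@H]1OC3` carries methyl in place of hydrogen on a saturated chain carbon bound to an oxygen on an aromatic ring and so turns methoxy into ethoxy. Going by the values given here, no measured step bears on this change, so no step beyond the scatter is expected in this assay in either direction. The estimated outcome is a step that the limit leaves unreadable from compound 2 to compound 3 and nothing firmer. For compound 3 the estimate is 5000 nM with an expected range from 2500 nM to 10000 nM at this stage.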

Compound 3, half-maximal inhibitory concentration: > 4000 nM
Compound 3: only a limit was reported (the forecaster's own chance of this, stated with the estimate: 45%); the middle value does not contradict the limit.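

Compound 3 reads > 4000 nM in this assay, which is a limit, so no new step can be read among compound 1, compound 2 and compound 3. The compounds shown leave open whether methoxy to ethoxy changes inhibition at all.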